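The compounds below may be only part of what the source reports. "The series", "measured", "known", "first", "only" and "open" are said of these compounds alone.

Of the compounds shown here, three built on one shared core have so far been tested in an assay on HEK293 cells for inhibition of kynurenine 3-monooxygenase (Homo sapiens), read by LC-MS, with a stated time of 20 h; on this read-out lower numbers stand for stronger inhibition and higher numbers for weaker inhibition. Compound 1 `CCOc1cc2oc(=O)n(CCC(=O)O)c2cc1Cl` gives 398 nM. Compound 2 `C[C@@H](Oc1cc2oc(=O)n(CCC(=O)O)c2cc1Cl)c1cccnn1` gives 631 nM, and compound 3 `O=C(O)CCn1c(=O)oc2cc(Cl)c(Cl)cc21` gives 2000 nM, the highest of the three numbers and therefore the weakest inhibitor of the set. The change that leads to compound 4 `O=C(O)CCn1c(=O)oc2cc(OCC3CCC3)c(Cl)cc21` is cyclobutylmethoxy in place of chloro on an aromatic carbon. Within the data shown here, one measured step bears directly on it: a 5.0-fold higher number from compound 1 to compound 3 (0.70 log units; beyond the scatter), which is the exchange of chloro for a group attached through oxygen, run in the opposite direction. Reversing that exchange on compound 3 should bring the number back down. A second step, a 1.6-fold higher number from compound 1 to compound 2 (0.20 log units; within the scatter), shows that making the group on that oxygen larger did little. Compound 4 is therefore expected to land close to compound 1, and the step of a 5.7-fold lower number from compound 3 to compound 4 (0.76 log units; beyond the scatter) is estimated accordingly. The estimate for compound 4 is 350 nM, with a range from 120 nM to 1000 nM.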

Compound 4, half-maximal inhibitory concentration in the kynurenine 3-monooxygenase assay: 1260 nM
Compound 4: middle estimate off by 3.6-fold (0.56 log units), on the low side; measured number above the stated range.
By their numbers in the kynurenine 3-monooxygenase assay, from the lowest: compounds 1, 2, 4 and 3 (each within the scatter of the next, the first and the last beyond it).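

At this position, a group attached through oxygen is not enough on its own to lower the number: in the kynurenine 3-monooxygenase assay, cyclobutylmethoxy in place of chloro gives a 1.6-fold lower number from compound 3 to compound 4 (0.20 log units; within the scatter). What sits on that oxygen also counts: cyclobutyl in place of methyl on the chain gives a 3.2-fold higher number from compound 1 to compound 4 (0.50 log units; beyond the scatter), whereas exchanging the group with the six-membered aromatic ring for the one with the four-membered ring gives a 2.0-fold higher number from compound 2 to compound 4 (0.30 log units; within the scatter). In a physicochemical assay for lipophilicity, read by HPLC, at pH 7.4 (a higher number here means a more lipophilic compound, a lower number a more polar compound), compound 3 gives 1.61 and compound 4 gives 2.9, yet their numbers in the kynurenine 3-monooxygenase assay lie within the scatter of each other.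

The compounds shown leave open how a methoxy group or a longer straight chain on that oxygen would compare with ethoxy. They also leave open what an amine at the end of that chain would do.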